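This account rests on a few compounds, and the source may have more. Where it says the series, first, only, none or still open, it means among the compounds named here.

Three sulfonamides built on one shared core have been tested in an assay on cells for inhibition of HSP60/HSP10 (Homo sapiens), with a stated time of 60 min; a lower number here means a stronger inhibitor, a higher number a weaker inhibitor. Compound 1 `Cc1ccccc1S(=O)(=O)Nc1ccc2oc(-c3ccccc3)nc2c1` is the methyl-bearing member of the set. In this assay compound 1 gives > 100000 nM, which is a limit of the assay rather than a measured number. Compound 2 `O=S(=O)(Nc1ccc2oc(-c3ccccc3)nc2c1)c1cccc(C(F)(F)F)c1` carries a trifluoromethyl group instead. In this assay compound 2 gives > 100000 nM, again only a limit. Compound 3 `O=S(=O)(Nc1ccc2oc(-c3ccccc3)nc2c1)c1ccccc1Cl` has a chloro group in place of the methyl. In this assay compound 3 gives > 100000 nM, also a limit. Compound 3 therefore stands at the same limit as the other two, and no ranking among the three can be read from these values.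

Going by the values given here, the only measured step, a step that the two limits leave unreadable from compound 1 to compound 3, cannot be sized because of the limit of > 100000 nM in this assay, at which 3 of the 3 values shown sit.

Compound 4 `Cc1cccc(S(=O)(=O)Nc2ccc3oc(-c4ccccc4)nc3c2)c1` differs from compound 3 by 3-methylphenyl in place of 2-chlorophenyl on a sulfonyl sulfur. Among the compounds with values here, no measured step bears on this particular change, and the one step that exists gives no size. Within the data shown here, with every value so far sitting at the limit, the step of a number no higher from compound 3 to compound 4 (the limit leaves the size open) is expected to show no movement beyond the scatter in either direction. Compound 4 is accordingly estimated at 100000 nM, within a range from 30000 nM to 300000 nM, with the likeliest outcome being that this assay again reports only the limit.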

Compound 4, half-maximal inhibitory concentration: > 100000 nM
Compound 4 was reported as a limit; the forecaster's own chance of this, stated with the estimate: 85%; the middle value lies on the limit itself.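

Compound 4 gives a limit in this assay, as do compound 1, compound 2 and compound 3, so no step among these four can be read, because every value sits at the same limit: the limit of > 100000 nM in this assay, at which 4 of the 4 values shown sit.

The compounds shown leave open whether any compound on the shared core gives a measured number rather than a limit, and how these four rank against one another.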